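This account rests on a few compounds, and the source may have more. Where it says the series, first, only, none or still open, it means among the compounds named here.

For the measured compounds named here, in an assay on isolated protein (urine) for inhibition of Myeloperoxidase (Homo sapiens), with a stated time of 5 min (on this read-out higher numbers stand for weaker inhibition and lower numbers for stronger inhibition), compound 1 `NCCCc1c[nH]c2c(F)cccc12` gives 24 nM, one of only two numbers reported here. The other number belongs to compound 3 `NC(=O)CCCCc1c[nH]c2ccc(F)cc12`, which in this assay gives 39 nM, a value that sits within the usual scatter of the figure for compound 1. Compound 2 `CCCc1c[nH]c2ccc(F)cc12` yields only a limit in this assay, > 100 nM; that limit is described as the limit of > 100 nM in this assay, at which 1 of the 3 values shown sits.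

Compound 4 `NCCCCc1c[nH]c2c(F)cccc12` differs from compound 1 by aminomethyl in place of amino on a saturated chain carbon, three bonds along the chain from an aromatic carbon. Going by the values given here, the single measured step with any bearing on it is an at least 2.5-fold lower number from compound 2 to compound 3 (0.40 log units; beyond the scatter), which lengthens a chain on the same kind of carbon, but it starts from a limit and its group is not an amine. That step is therefore only a loose guide, and nothing in the data shows that one added chain carbon before an amine changes this assay beyond the scatter. Compound 4 is accordingly expected to show a 1.2-fold higher number from compound 1 to compound 4 (0.07 log units; within the scatter), and its value in this assay is estimated at 28 nM, within a range from 10 nM to 80 nM.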

Compound 4, half-maximal inhibitory concentration: 6 nM
Compound 4: middle estimate off by 4.7-fold (0.67 log units), on the high side; measured number below the stated range.
By their numbers in this assay, from the lowest: compound 4; then compounds 1 and 3 (each within the scatter of the next). At a limit, above all of these: compound 2.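

In this assay, replacing the 3-aminopropyl chain with the 4-aminobutyl chain gives a 4.0-fold lower number from compound 1 to compound 4 (0.60 log units; beyond the scatter). This is the first step shown in which the amine stays and only the chain grows, and because it lies beyond the scatter, it shows that the length of the amine-bearing chain at this position matters on this read-out. No measurement shown here accounts for the size of this step.

Two compounds cannot show whether a longer chain, such as 5-aminopentyl, would lower the number further or raise it again, or whether a hydroxyl group or a carboxylic acid could replace the amine on the 4-aminobutyl chain. On these data alone, it also remains open whether the same chain extension would have a similar effect on the core of compound 3.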